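The source may report more compounds than this note shows. Statements on the series, on what has been measured and on what is new or still open speak of the compounds shown alone.

In an ADME assay on LLC-MK2 cells (Macaca mulatta) for cytotoxicity, read by spectrophotometry and crystal violet staining, with a stated time of 4 days (a higher number here means that more compound is tolerated, a lower number that less compound is tolerated), the three measured compounds stand as follows. Compound 1 `CC(C)n1ncc2c(C(=O)Nc3c(F)cc(F)cc3F)cc(-c3cccs3)nc21`: > 200000 nM, a limit of the assay. Compound 2 `CC(C)n1ncc2c(C(=O)Nc3cccc(F)c3)cc(-c3cccs3)nc21`: > 200000 nM, a limit of the assay. Compound 3 `CC(C)n1ncc2c(C(=O)Nc3cc(C(N)=O)ccc3F)cc(-c3cccs3)nc21`: 25000 nM.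

Among the measured compounds shown here, compound 3 therefore holds the only number among the three; the other two values sit at the limit of > 200000 nM in this assay, at which 2 of the 3 values shown sit. The step of an at least 8.0-fold lower number from compound 1 to compound 3 (0.90 log units; beyond the scatter) and the step of an at least 8.0-fold lower number from compound 2 to compound 3 (0.90 log units; beyond the scatter) both lower the number, and in each the 5-carbamoyl-2-fluorophenyl enters. The step that the two limits leave unreadable from compound 1 to compound 2 cannot be read. Compound 4 `CC(C)n1ncc2c(C(=O)Nc3ccccc3S(N)(=O)=O)cc(-c3cccs3)nc21` differs from compound 3 by 2-sulfamoylphenyl in place of 5-carbamoyl-2-fluorophenyl on an amide-type nitrogen. For the measured compounds named here, no measured step involves a 2-sulfamoylphenyl, so no step bears directly on this change. For compound 4 the outcome is expected to be no change at the digits printed from compound 3 to compound 4 (within the scatter), within the scatter. Compound 4 is estimated at 25000 nM, between 8000 nM and 200000 nM.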

Compound 4, half-maximal cytotoxic concentration: 25000 nM
Compound 4: the middle estimate sits on the measured number at the digits printed; measured number inside the range.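

In this assay, placing 2-sulfamoylphenyl on the amide-type nitrogen in place of 5-carbamoyl-2-fluorophenyl gives no change at the digits printed from compound 3 to compound 4 (within the scatter), so the lower number is not tied to the carbamoyl group or to a fluorine on this ring. Against the fluorinated phenyl groups, the same change gives an at least 8.0-fold lower number from compound 2 to compound 4 (0.90 log units; beyond the scatter) and an at least 8.0-fold lower number from compound 1 to compound 4 (0.90 log units; beyond the scatter). Both steps start from a limit of the assay: the limit of > 200000 nM in this assay, at which 2 of the 4 values shown sit.

The compounds shown leave open where an unsubstituted phenyl would fall. They also leave open whether a carboxylic acid or an amine on this ring would stand with compound 3 and compound 4.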